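Ethynyl in place of thiophen-2-yl on the shared core

This account rests on a few compounds, and the source may have more. Where it says the series, first, only, none or still open, it means among the compounds named here.

Measured in an ADME assay on MRC5 cells (Homo sapiens), read by MTT assay, with a stated time of 72 h; on this read-out lower numbers stand for stronger inhibition and higher numbers for weaker inhibition:
Compound 1 (`C#Cc1cn([C@@H]2O[C@H](CO)[C@@H](O)[C@H]2O)c2ncnc(NC)c12`): > 100000 nM (a limit)
Compound 2 (`Cc1ncnc2c1c(-c1ccoc1)cn2[C@@H]1O[C@H](CO)[C@@H](O)[C@H]1O`): 98300 nM
Compound 3 (`Cc1ncnc2c1c(-c1cccs1)cn2[C@@H]1O[C@H](CO)[C@@H](O)[C@H]1O`): > 100000 nM (a limit)

Compound 3 stands at > 100000 nM in this assay as a limit and not as a number. The readings so far end upward at the limit of > 100000 nM in this assay, at which 2 of the 3 values shown sit, in most cases. Compound 4 (`C#Cc1cn([C@@H]2O[C@H](CO)[C@@H](O)[C@H]2O)c2ncnc(C)c12`) differs from compound 3 by one change, ethynyl in place of thiophen-2-yl on an aromatic carbon. Within the data shown here, the one measured step bearing on this is an at least 1.0-fold higher number from compound 2 to compound 3 (0.00 log units; that floor lies within the scatter) and it gives no sign of a shift. Compound 1 also carries ethynyl, and its > 100000 nM is likewise a limit. The expected step is therefore an at least 1.2-fold lower number from compound 3 to compound 4 (0.09 log units; that floor lies within the scatter) and nothing beyond the scatter is expected. For compound 4 the estimated value is 80000 nM (expected range 10000 nM to 100000 nM).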

Compound 4, half-maximal inhibitory concentration: 1440 nM
Beside the measured number, compound 4's estimate is 56-fold (1.74 log units) above it; measured number below the stated range.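

In this assay, ethynyl on this aromatic carbon gives a large drop, an at least 69-fold lower number from compound 3 to compound 4 (1.84 log units; beyond the scatter) and a 68-fold lower number from compound 2 to compound 4 (1.83 log units; beyond the scatter), whereas thiophen-2-yl in place of furan-3-yl showed no shift beyond the scatter. Ethynyl does not suffice alone, since methyl in place of methylamino on another aromatic carbon of the shared core also gives a large step, an at least 69-fold lower number from compound 1 to compound 4 (1.84 log units; beyond the scatter). Compound 1 and compound 3 each stand at a limit, so these two steps are floors: the limit of > 100000 nM in this assay, at which 2 of the 4 values shown sit.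

Going by these compounds, what a nitrile, a bromine atom or a longer alkyne chain would do on this carbon remains open.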